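This account rests on a few compounds, and the source may have more. Where it says the series, first, only, none or still open, it means among the compounds named here.

Measured compounds:
compound 1 `O=C(Nc1cccc(-c2nc(-c3ccc(NC(=O)c4cccnc4)cc3Cl)no2)c1)Nc1cccc(C(F)(F)F)c1` — 1900 nM
compound 2 `COc1cccc(NC(=O)Nc2cccc(-c3nc(-c4ccc(NC(=O)c5cccnc5)cc4Cl)no3)c2)c1` — 6700 nM
compound 3 `NS(=O)(=O)Nc1ccc(NC(=O)Nc2cccc(-c3nc(-c4ccc(NC(=O)c5cccnc5)cc4Cl)no3)c2)cc1` — 8900 nM

In a functional assay on MDA-MB-231 cells (Homo sapiens) for antiproliferative activity, read by MTT assay, with a stated time of 72 h (a higher number here means a weaker inhibitor, a lower number a stronger inhibitor), compound 3 stands highest of the three numbers. Its nearest neighbour is compound 2, the gap being a 1.3-fold higher number from compound 2 to compound 3 (0.12 log units; within the scatter); the furthest is compound 1, with a 4.7-fold higher number from compound 1 to compound 3 (0.67 log units; beyond the scatter). Compound 4 `CS(=O)(=O)Nc1cccc(NC(=O)Nc2cccc(-c3nc(-c4ccc(NC(=O)c5cccnc5)cc4Cl)no3)c2)c1` differs from compound 3 by 3-(methanesulfonamido)phenyl in place of 4-(sulfamoylamino)phenyl on an amide-type nitrogen. For the measured compounds named here, the steps that bear on this change are those among the urea substituents: a 3.5-fold higher number from compound 1 to compound 2 (0.55 log units; beyond the scatter), a 4.7-fold higher number from compound 1 to compound 3 (0.67 log units; beyond the scatter) and a 1.3-fold higher number from compound 2 to compound 3 (0.12 log units; within the scatter). The two substituted aryl groups that are not trifluoromethyl-bearing sit close together, so the new sulfonamide-bearing aryl group is expected to give a number near compound 3, with no step beyond the scatter. Compound 4 is therefore estimated at 6500 nM, with a range of 2500 nM to 16000 nM. The expected step is a 1.4-fold lower number from compound 3 to compound 4 (0.14 log units; within the scatter).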

Compound 4, half-maximal inhibitory concentration: > 10000 nM
Compound 4 was reported as a limit (the forecaster's own chance of this, stated with the estimate: 5%); middle value at least 1.5-fold (0.18 log units) from the limit.
By their numbers in this assay, from the lowest: compound 1; then compounds 2 and 3 (each within the scatter of the next). At a limit, above all of these: compound 4.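

Compound 4 in this assay is a limit and not a number: the limit of > 10000 nM in this assay, at which 1 of the 4 values shown sits. Even so, the change can be read against the trifluoromethyl compound, with an at least 5.2-fold higher number from compound 1 to compound 4 (0.72 log units; beyond the scatter), so a third group on this amide-type nitrogen falls beyond the scatter from compound 1. The floors of an at least 1.1-fold higher number from compound 3 to compound 4 (0.05 log units; that floor lies within the scatter) and an at least 1.4-fold higher number from compound 2 to compound 4 (0.17 log units; that floor lies within the scatter) lie within the scatter, so they set no order among these compounds.

The compounds shown leave open how far compound 4 lies past its limit. They also leave open what an amine or a carboxylic acid on this phenyl would give in place of methanesulfonamido.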